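The source may report more compounds than this note shows. Statements on the series, on what has been measured and on what is new or still open speak of the compounds shown alone.

Measured so far in a functional assay on MCF7 cells (Homo sapiens) for inhibition, read by MTT assay, with a stated time of 72 h (on this read-out higher numbers stand for weaker inhibition and lower numbers for stronger inhibition), on the shared core:
Compound 1 `Cc1cc2occ(-c3nc(-c4ccccc4)c(-c4ccccc4)n3-c3ccc([N+](=O)[O-])cc3)c(=O)c2cc1Cl` gives 6250 nM
Compound 2 `COc1ccccc1-n1c(-c2coc3cc(C)c(Cl)cc3c2=O)nc(-c2ccccc2)c1-c1ccccc1` gives 25000 nM
Compound 3 `Cc1ccc(-n2c(-c3coc4cc(C)c(Cl)cc4c3=O)nc(-c3ccccc3)c2-c2ccccc2)c(C)c1` gives 6250 nM

Of these three, compound 2 has the highest number and so shows the weakest inhibition, with its steps to both others beyond the scatter. The unmeasured compound 4 `Cc1cc2occ(-c3nc(-c4ccccc4)c(-c4ccccc4)n3-c3ccc(Cl)cc3)c(=O)c2cc1Cl` differs from compound 2 by a single change 4-chlorophenyl in place of 2-methoxyphenyl on an aromatic nitrogen that puts 4-chlorophenyl in place of 2-methoxyphenyl on an aromatic nitrogen.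

Two measured steps involve this same place. The step of a 4.0-fold higher number from compound 1 to compound 2 (0.60 log units; beyond the scatter) came with 2-methoxyphenyl replacing 4-nitrophenyl. The step of a 4.0-fold lower number from compound 2 to compound 3 (0.60 log units; beyond the scatter) came with 2,4-dimethylphenyl replacing 2-methoxyphenyl. The third step of no change at the digits printed from compound 1 to compound 3 (within the scatter) shows no separation between those two replacement groups. So far, then, both groups tried instead of 2-methoxyphenyl gave the same lower number, and no measured compound goes against this. Neither group is 4-chlorophenyl, however, so the guide is only a loose one.

The expected change in this assay is a modest one towards stronger inhibition, estimated as a 4.0-fold lower number from compound 2 to compound 4 (0.60 log units; beyond the scatter) and similar in size to the two steps above. For compound 4 the estimated value is 6250 nM with an expected range of 2000 nM to 20000 nM in this assay.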

Compound 4, half-maximal inhibitory concentration: 12500 nM
The estimate for compound 4 lay 2.0-fold (0.30 log units) below the measured number, within the range that was stated.
By their numbers in this assay, from the lowest: compounds 1, 3, 4 and 2 (each within the scatter of the next, the first and the last beyond it).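

In this assay, 4-chlorophenyl on the aromatic nitrogen gives a number within the scatter of all three earlier compounds: a 2.0-fold lower number from compound 2 to compound 4 (0.30 log units; within the scatter), a 2.0-fold higher number from compound 3 to compound 4 (0.30 log units; within the scatter) and, with chloro in place of nitro on an aromatic carbon, a 2.0-fold higher number from compound 1 to compound 4 (0.30 log units; within the scatter). The earlier compounds shown here seemed to fall into two levels, with compound 2 apart from compounds 1 and 3, but compound 4 cannot be assigned to either level, so that split now rests on a single modest gap among four closely spaced numbers. No available finding accounts for how close these numbers are.

From the compounds shown here alone, all four compounds carry a substituted phenyl group at this place, so it remains open how the unsubstituted phenyl group, a pyridine ring or a saturated group such as cyclohexyl would read out here. Also open, going by these compounds, is whether an amine or a carboxylic acid on this phenyl ring, or a change to the two phenyl groups elsewhere on the shared core, would produce a larger step than any seen so far.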